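A few compounds are considered here, and "the series" means these few. Any claim that something is new, unique, unknown or untested is made for them only; others in the source may bear on it.

Values in a functional assay on DU-145 cells (Homo sapiens) for inhibition, read by trypan blue exclusion, with a stated time of 96 h (on this read-out lower numbers stand for stronger inhibition of growth and higher numbers for weaker inhibition of growth), for the three measured compounds:
Compound 1 `O=C(/C(=C\c1ccc([N+](=O)[O-])c(O)c1)SCc1ccc(Br)cc1)c1ccc(C(F)(F)F)cc1` gives 1000 nM
Compound 2 `O=C(O)c1ccc(C(=O)/C(=C\c2ccc([N+](=O)[O-])c(O)c2)SCc2ccc(Br)cc2)cc1` gives 10000 nM
Compound 3 `O=C(/C(=C\c1ccc([N+](=O)[O-])c(O)c1)SCc1ccc(Br)cc1)C1CCNC1` gives > 100000 nM as a limit of the assay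

Of the two true numbers, compound 2 holds the higher one, with a 10-fold higher number from compound 1 to compound 2 (1.00 log units; beyond the scatter) as the gap. What stands for compound 3 is a limit and not a number.

In compound 4 `O=C(O)c1ccc(C(=O)/C(=C\c2ccc(O)c(Br)c2)SCc2ccc(Br)cc2)cc1` the rest of compound 2 is kept, and 3-bromo-4-hydroxyphenyl in place of 3-hydroxy-4-nitrophenyl on a double-bonded chain carbon bound to a double-bonded chain carbon is the whole structural change. Thus 3-bromo-4-hydroxyphenyl stands in place of 3-hydroxy-4-nitrophenyl on a double-bonded chain carbon bound to a double-bonded chain carbon.

All three measured steps alter the other end of the molecule, at the group on the carbonyl carbon, and none touches this group. They are modest in a 10-fold higher number from compound 1 to compound 2 (1.00 log units; beyond the scatter) and large in an at least 100-fold higher number from compound 1 to compound 3 (2.00 log units; beyond the scatter) and at least modest in an at least 10-fold higher number from compound 2 to compound 3 (1.00 log units; beyond the scatter) in size. They give no direction for the new change, though they do show that numbers in this small set can move well beyond the scatter. No shift in either direction is therefore assumed, and a wide range is kept.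

The step expected in this assay is no change at the digits printed from compound 2 to compound 4 (within the scatter) and it remains only an estimate.

For compound 4 the estimated value is 10000 nM with an expected range from 2000 nM to 50000 nM in this read-out.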

Compound 4, concentration for 50% growth inhibition: 25000 nM
Compound 4: the middle estimate sits 2.5-fold (0.40 log units) below what was measured; measured number inside the range.
By their numbers in this assay, from the lowest: compound 1; then compound 2; then compound 4. At a limit, above all of these: compound 3.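

Within the data shown here, the earlier steps all lay at the group on the carbonyl carbon, so this is the first reading at the group on a double-bonded chain carbon bound to a double-bonded chain carbon: in this assay, 3-bromo-4-hydroxyphenyl in place of 3-hydroxy-4-nitrophenyl gives a 2.5-fold higher number from compound 2 to compound 4 (0.40 log units; beyond the scatter). The number therefore responds to a change at this position as well, although this step is smaller than the one at the carbonyl carbon, a 10-fold higher number from compound 1 to compound 2 (1.00 log units; beyond the scatter). Nothing measured here bears on why the number moved with this change.

This single change removes the nitro group, brings in the bromine and shifts the hydroxy group together, and the compounds shown cannot separate these parts. As far as these compounds go, it remains open whether an amine or a methoxy group on this aromatic ring would give a similar number, and whether the same change would read alike with the 4-(trifluoromethyl)phenyl group of compound 1 on the carbonyl carbon.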